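This account rests on a few compounds, and the source may have more. Where it says the series, first, only, none or still open, it means among the compounds named here.

Measured set:
Compound 1 `Nc1n[nH]c2cc(-c3ccc(=O)n(Cc4cccc(Cl)c4)c3)ccc12`; in an assay for inhibition of MAP kinase-interacting serine/threonine-protein kinase 2 (Homo sapiens), read by luminescence and ADP-Glo, with a stated time of 2 h (on this read-out lower numbers stand for stronger inhibition and higher numbers for weaker inhibition), compound 1 gives 6 nM.
Compound 3 `O=c1ccc(-c2ccc3cn[nH]c3c2)cn1Cc1cccc(Cl)c1`; compound 3 gives 40 nM.
Compound 2 `Cn1ncc2ccc(-c3ccc(=O)n(Cc4ccccc4)c3)cc21`; compound 2 reaches only the assay limit, > 2000 nM.

Compound 1 holds the lowest of the two numbers; its nearest neighbour is compound 3, one change away: a 6.7-fold higher number from compound 1 to compound 3 (0.82 log units; beyond the scatter). Compound 4 `Nc1n[nH]c2cc(-c3ccc(=O)n(Cc4ccccc4)c3)ccc12` differs from compound 1 by hydrogen in place of chloro on an aromatic carbon. Within the data shown here, no measured step touches this group; the amino change is elsewhere on the shared core and does not transfer. Compound 2 also carries a benzyl but differs in further places, so its limit of > 2000 nM in this assay, at which 1 of the 3 values shown sits, cannot be tied to the chloro. A small rise beyond the scatter is expected, a 2.5-fold higher number from compound 1 to compound 4 (0.40 log units; beyond the scatter), with compound 4 estimated at 15 nM, range 5 nM to 50 nM.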

Compound 4, half-maximal inhibitory concentration: 32 nM
Beside the measured number, compound 4's estimate is 2.1-fold (0.33 log units) below it; low and high end bracket the measured number.
By their numbers in this assay, from the lowest: compound 1; then compounds 4 and 3 (each within the scatter of the next). At a limit, above all of these: compound 2.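

In this assay, the change from 3-chlorobenzyl to benzyl, with the amino group on the shared core kept, gives a 5.3-fold higher number from compound 1 to compound 4 (0.73 log units; beyond the scatter). Among these compounds, this is the first direct reading at this place on the six-membered aromatic ring: the chloro counts for more than the scatter, yet inhibition persists without it, with compound 4 at 32 nM. Nothing shown here accounts for the step.

Open, from the compounds shown here alone, is how a fluoro, methyl or methoxy group would read at this place. Also open, going by these compounds, is whether the amino and chloro steps add together on the shared core.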